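The source may hold more compounds than are shown below. What is called first, only, known or untested is meant among the compounds shown, and "the series" means these compounds.

Measured compounds:
Compound 1, `CC(C)(C)C1=CC(=O)C=C(NCCC(=O)O)C1=O`, gives 67000 nM.
Compound 2, `CC(C)(C)C1=CC(=O)C=C(NCC(=O)O)C1=O`, gives 85000 nM.
Compound 3, `CC1=CCC[C@H]2[C@](C)(CC3=CC(=O)C=C(NCCC(=O)O)C3=O)[C@@H](C)CC[C@]12C`, gives 15500 nM.

All three values come from a functional assay on K562 cells (Homo sapiens) for cytotoxicity, read by MTT assay, with a stated time of 72 h; on this read-out lower numbers stand for stronger inhibition and higher numbers for weaker inhibition. Compound 1 and compound 2 share one core and differ in a single place: carboxy in place of carboxymethyl on a saturated chain carbon bound to an amine nitrogen. That change produced a 1.3-fold higher number from compound 1 to compound 2 (0.10 log units; within the scatter), so the two values cannot be told apart within the usual scatter. Compound 3 carries a different core; how the core of compound 3 differs from the core of compound 1 is not broken down here, and the two compounds can be compared only through their values, where compound 3 shows the lowest number of the three measured compounds, with both others beyond the scatter above it.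

Compound 4, `CC1=CCC[C@H]2[C@](C)(CC3=CC(=O)C=C(NCC(=O)O)C3=O)[C@@H](C)CC[C@]12C`, has not yet been measured in this assay. It relates to compound 3 exactly as compound 2 relates to compound 1: carboxy in place of carboxymethyl on a saturated chain carbon bound to an amine nitrogen. The place is the same in both pairs, so this is the same change made on the core of compound 3 rather than on the core of compound 1. Within the data shown here, only one earlier instance of the change is available, and it rests on a single pair, so the expectation for compound 4 follows from compound 1 and compound 2, where the change gave a 1.3-fold higher number from compound 1 to compound 2 (0.10 log units; within the scatter). Compound 4 is therefore expected to show a 1.2-fold higher number from compound 3 to compound 4 (0.09 log units; within the scatter) in this assay. Compound 4 is estimated at 19000 nM, with the estimate spanning from 9000 nM to 40000 nM.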

Compound 4, half-maximal inhibitory concentration: 15600 nM
Estimate against measurement, compound 4: 1.2-fold (0.09 log units) above; the measured number falls inside the stated range.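

In this assay, the swap from (2-carboxyethyl)amino to (carboxymethyl)amino on the core of compound 3 gave a 1.0-fold higher number from compound 3 to compound 4 (0.00 log units; within the scatter), so the two values cannot be told apart. Compared with the earlier pair, the change behaves alike on both cores, with no difference that can be separated from the usual scatter: the same change on two cores in this assay, a 1.3-fold higher number (0.10 log units; within the scatter) from compound 1 to compound 2 and a 1.0-fold higher number (0.00 log units; within the scatter) from compound 3 to compound 4, 1.3-fold (0.10 log units) apart, within the scatter of two such steps. Among these compounds, this shows that in this assay, on these two cores, shortening the chain leaves the number within the scatter, but it rests on only two pairs, neither of which shows a step beyond the scatter, so it sets no rule for any other core and says nothing about why the values stay together.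

The compounds shown leave open whether a longer chain ending in a carboxylic acid would hold the number on either core, and whether a methyl ester, a primary amide or an amine in place of the carboxylic acid would move it. They also leave open whether the same swap would stay within the scatter on a third core, or in a cell line other than the one tested here.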